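The source may hold more compounds than are shown below. What is called first, only, known or untested is meant among the compounds shown, and "the series" means these compounds.

Of the compounds shown here, three built on a shared core have been tested in an assay on HEK293 cells for inhibition of sodium-dependent dopamine transporter (Homo sapiens), read by scintillation counting, with a stated time of 5 min; a lower number here means a stronger inhibitor, a higher number a weaker inhibitor. Compound 1 `CCN(C(=O)c1ccc(Cl)c(Cl)c1C)[C@@H]1CCNC1` returns only a limit of the assay in this assay, > 40000 nM. Compound 2 `Cc1c(CN([C@@H]2CCNC2)S(C)(=O)=O)ccc2cc(F)ccc12` also returns only a limit in this assay, > 28000 nM. Compound 3 `O=C(c1ccc2ccccc2c1)N(C1CCC1)[C@@H]1CCNC1`, which carries a cyclobutyl on its amide nitrogen and a different aromatic part, gives 5800 nM in this assay. Compound 1 therefore stands at one of the two limits shown and has no number of its own: one of the three values sits at the limit of > 40000 nM in this assay, at which 1 of the 3 values shown sits, one at the limit of > 28000 nM in this assay, at which 1 of the 3 values shown sits, and only compound 3 gives a numerical reading.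

Compound 4 `Cc1c(C(=O)N(C(C)C)[C@@H]2CCNC2)ccc(Cl)c1Cl` differs from compound 1 in one place: methyl in place of hydrogen on a saturated chain carbon bound to an amide-type nitrogen and a saturated chain carbon. Within the data shown here, no measured pair differs in just this way, so the size of this step cannot be read from the data. Compound 1 sits at a limit of the assay. Compound 3 gives 5800 nM only together with a different aromatic part, so the step is expected to be a step that the limit leaves unreadable from compound 1 to compound 4, no change beyond the scatter. Compound 4 is expected to give about 50000 nM in this assay, from 15000 nM to 200000 nM, most likely again only as a limit.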

Compound 4, half-maximal inhibitory concentration: > 40000 nM
Compound 4: no number, only a limit; the forecaster's own chance of this, stated with the estimate: 60%; the middle value is on the limit's open side.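

Compound 1 and compound 4 both return only a limit of the assay in this assay, so the size of the step between them cannot be read: (the limit of > 40000 nM in this assay, at which 2 of the 4 values shown sit). The compounds shown leave open whether the change from ethyl to isopropyl alters the reading in this assay at all, and by how much.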